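Notes on the step from compound 3 to compound 4

The source may hold more compounds than are shown below. What is called first, only, known or untested is meant among the compounds shown, and "the series" means these compounds.

Compound 3 `COc1cc(C(c2ccc(O)c(OC)c2)[C@@H](C)[C@H](C)CO)ccc1O` gives > 100000 nM in a functional assay on HeLa cells (Homo sapiens) for cytotoxicity, read by WST assay, with a stated time of 48 h (a higher number here means a weaker inhibitor, a lower number a stronger inhibitor), which is a limit and not a number. Its place in the series is known only through (the limit of > 100000 nM in this assay, at which 1 of the 3 values shown sits). In this assay compound 1 `COc1cc(C(c2ccc(O)c(OC)c2)[C@H](C)C(C)C)ccc1O` gives 16000 nM and compound 2 `COC[C@H](C)[C@@H](C)C(c1ccc(O)c(OC)c1)c1ccc(O)c(OC)c1` gives 77000 nM.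

Compound 4 `COc1cc(C(c2ccc(O)c(OC)c2)[C@H](CC(C)C)C(C)C)ccc1O` carries 1-isopropyl-3-methylbutyl in place of 2-(hydroxymethyl)-1-methylpropyl on a saturated chain carbon bound to two aromatic carbons. The entering group has no oxygen, as does the 1,2-dimethylpropyl of compound 1.

Within the data shown here, two measured steps bear on this change. The modest 4.8-fold higher number from compound 1 to compound 2 (0.68 log units; beyond the scatter) and the at least modest an at least 6.2-fold higher number from compound 1 to compound 3 (0.79 log units; beyond the scatter) both lie beyond the scatter, and both lead to a chain with oxygen and a higher number. The floor of an at least 1.2-fold higher number from compound 2 to compound 3 (0.11 log units; that floor lies within the scatter) lies within the scatter, so these two compounds stay unordered. Among these three compounds, the one without oxygen in the chain has the lowest number, and none goes against this.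

Read in reverse, an at least 6.2-fold higher number from compound 1 to compound 3 (0.79 log units; beyond the scatter) points to a modest or larger step towards a lower number. Among the measured compounds shown here, no measured compound carries a group as large as the entering one, so the range stays wide. The expected change is an at least 8.3-fold lower number from compound 3 to compound 4 (0.92 log units; beyond the scatter). Compound 4 is expected at 12000 nM, with an estimated range of 3000 nM to 50000 nM.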

Compound 4, half-maximal inhibitory concentration: 8200 nM
For compound 4 the middle estimate is 1.5-fold (0.17 log units) above the measured one; the measured number falls inside the stated range.
By their numbers in this assay, from the lowest: compounds 4 and 1 (each within the scatter of the next); then compound 2. At a limit, above all of these: compound 3.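

On the saturated chain carbon bound to two aromatic carbons, 1-isopropyl-3-methylbutyl gives an at least 12-fold lower number from compound 3 to compound 4 (1.08 log units; beyond the scatter) and a 9.4-fold lower number from compound 2 to compound 4 (0.97 log units; beyond the scatter), so in this assay a chain without oxygen goes with the lower number in a second compound, and none of the four goes against this. The first of these steps rests on a limit for compound 3 and not on a number: the limit of > 100000 nM in this assay, at which 1 of the 4 values shown sits. The added isopropyl gives no readable change, with a 2.0-fold lower number from compound 1 to compound 4 (0.29 log units; within the scatter) lying within the scatter, so 1-isopropyl-3-methylbutyl and the 1,2-dimethylpropyl of compound 1 stay unordered and the larger chain shows no gain over the smaller one.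

The compounds shown leave open whether an amine or a carboxylic acid at the chain end would fall with the hydroxymethyl and methoxymethyl chains of compound 3 and compound 2, or whether those high numbers belong to oxygen alone. They also leave open whether a longer chain without oxygen, such as n-hexyl, would stay level with compound 1 and compound 4 or move away from them.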